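The source may report more compounds than this note shows. Statements on the series, on what has been measured and on what is new or still open speak of the compounds shown alone.

Measured so far in an assay on isolated protein for displacement of a labelled ligand from secreted frizzled-related protein 1 (Homo sapiens), read by fluorescence polarization, with a stated time of 30 min; on this read-out lower numbers stand for stronger inhibition and higher numbers for weaker inhibition:
Compound 1, `O=C(c1ccc(Cl)cc1)N1CCC(NS(=O)(=O)c2cc(S(=O)(=O)c3ccccc3)ccc2C(F)(F)F)CC1`, gives 300 nM.
Compound 2, `O=C(c1ccccn1)N1CCC(NS(=O)(=O)c2cc(S(=O)(=O)c3ccccc3)ccc2C(F)(F)F)CC1`, gives 60 nM.
Compound 3, `O=C(O)CCCC(=O)N1CCC(NS(=O)(=O)c2cc(S(=O)(=O)c3ccccc3)ccc2C(F)(F)F)CC1`, gives 500 nM.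

Compound 2 gives the lowest number of the three in this assay; the steps of a 5.0-fold lower number from compound 1 to compound 2 (0.70 log units; beyond the scatter) and an 8.3-fold higher number from compound 2 to compound 3 (0.92 log units; beyond the scatter) both lie beyond the scatter, so compound 2 is the strongest inhibitor among those measured. Compound 4, `O=C([C@H]1CCNC1)N1CCC(NS(=O)(=O)c2cc(S(=O)(=O)c3ccccc3)ccc2C(F)(F)F)CC1`, is not yet measured. It differs from compound 2 in one place: pyrrolidin-3-yl in place of pyridin-2-yl on a carbonyl carbon.

Both measured steps touch this carbonyl carbon. The step of an 8.3-fold higher number from compound 2 to compound 3 (0.92 log units; beyond the scatter) shows a modest rise in the number when pyridin-2-yl gives way to a non-aromatic group, and the step of a 5.0-fold lower number from compound 1 to compound 2 (0.70 log units; beyond the scatter) shows that pyridin-2-yl gave the lowest number against 4-chlorophenyl. Compound 4 keeps a ring but one that is five-membered and non-aromatic, so a modest rise in the number in this assay is expected, probably smaller than the step to compound 3, yet beyond the scatter. For compound 4 the expected step is a 4.2-fold higher number from compound 2 to compound 4 (0.62 log units; beyond the scatter). The estimate for compound 4 in this assay is 250 nM, within 80 nM to 800 nM.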

Compound 4, half-maximal inhibitory concentration: 40 nM
Estimate against measurement, compound 4: 6.3-fold (0.80 log units) above; measured number below the stated range.
By their numbers in this assay, from the lowest: compounds 4 and 2 (each within the scatter of the next); then compounds 1 and 3 (each within the scatter of the next).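

In this assay, an aromatic ring on this carbonyl carbon is not required among the compounds shown: the step of a 1.5-fold lower number from compound 2 to compound 4 (0.18 log units; within the scatter) stays within the scatter, so the non-aromatic pyrrolidin-3-yl and pyridin-2-yl cannot be ranked. Pyrrolidin-3-yl also separates clearly from the two weaker groups, with the steps of a 7.5-fold lower number from compound 1 to compound 4 (0.88 log units; beyond the scatter) and a 13-fold lower number from compound 3 to compound 4 (1.10 log units; beyond the scatter) both beyond the scatter. Nothing measured here accounts for the close match between the two nitrogen-bearing rings.

Still open, going by these compounds, is whether the ring nitrogen matters at all, which a cyclopentyl group on the same carbonyl carbon would test. Also open, on these data alone, is how the opposite enantiomer of pyrrolidin-3-yl, a pyrrolidin-2-yl group or an open-chain amine would compare with compound 4.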